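From 4-aminophenyl to phenyl: an unmeasured step in mice

A few compounds are considered here, and "the series" means these few. Any claim that something is new, unique, unknown or untested is made for them only; others in the source may bear on it.

In a functional assay on the whole organism with Mus musculus as the target (a lower number here means that less compound is needed, a higher number that more compound is needed for the effect), compound 1 (`COc1cc2c(cc1OC)C(c1ccc(N)cc1)=NN=C(S)C2`) gives 38.5 umol/kg as its dose for half-maximal effect. In this assay, going by the values given here, compound 2 (`COc1cc2c(cc1OC)C(c1ccc(N)cc1)=NNC(=O)C2`) gives 58.2 umol/kg and the two numbers lie within the usual scatter of each other, so compound 1 stands level with the only other compound measured so far.

Compound 3 (`COc1cc2c(cc1OC)C(c1ccccc1)=NN=C(S)C2`) has yet to be measured. It differs from compound 1 by one structural change (hydrogen in place of amino on an aromatic carbon), which is hydrogen in place of amino on an aromatic carbon, para to a large group. Cut one bond further out, the change reads 4-aminophenyl to phenyl.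

Among the compounds with values here, both measured compounds carry the amino group, so no measured step shows what its loss does and any forecast remains uncertain. A moderate rise in the number is expected in this assay, meaning that more compound would be needed, although a result within the scatter remains possible. The estimated change is a 1.9-fold higher number from compound 1 to compound 3 (0.29 log units; within the scatter) and it is only a rough expectation. Compound 3 is estimated at 75 umol/kg with an expected range from 30 umol/kg to 190 umol/kg in this measurement.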

Compound 3, dose for half-maximal effect: 69.1 umol/kg
Estimate against measurement, compound 3: 1.1-fold (0.04 log units) above; low and high end bracket the measured number.
By their numbers in this assay, from the lowest: compounds 1, 2 and 3 (each within the scatter of the next).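

In this assay, hydrogen in place of amino on an aromatic carbon gives a 1.8-fold higher number from compound 1 to compound 3 (0.25 log units; within the scatter). Going by these compounds alone, this is the only measured step at this position, as both earlier compounds carry the amino group, and it lies within the scatter, so the assay does not separate the 4-aminophenyl compound from the phenyl compound and these numbers do not show that the amino group is needed for the effect in mice. No measurement is available that would explain this result, so the reading stops at the numbers themselves.

The compounds shown leave open whether other groups at this place, such as a methoxy group, a chlorine atom or a carboxylic acid, would stand apart from amino and hydrogen in this assay. Also open, as far as these compounds go, is how the same change would read on compound 2, as a single step at a single position in a single assay is all that speaks to it here.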